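Swapping Fluoro for Methyl: Cytotoxicity Outlook for Compound 4

This account rests on a few compounds, and the source may have more. Where it says the series, first, only, none or still open, it means among the compounds named here.

Of the compounds shown here, three built on one shared core have been tested in an ADME assay on MT2 cells (Homo sapiens) for cytotoxicity, read by XTT assay, with a stated time of 4 days; on this read-out lower numbers stand for higher toxicity in this test and higher numbers for lower toxicity in this test. Compound 1 `Cc1ccc(-c2c3c(nc(C)c2C(OC(C)(C)C)C(=O)O)CCN(CCCC2CCCC2)C3)cc1` returned a limit of > 40000 nM. Compound 3 `Cc1ccc(-c2c3c(nc(C)c2[C@H](OC(C)(C)C)C(=O)O)CCN(C/C=C/c2ccccc2)C3)cc1` likewise returned a limit of > 40000 nM. Compound 2 `Cc1nc2c(c(-c3cc(F)c4c(c3C)CCCO4)c1[C@H](OC(C)(C)C)C(=O)O)CN(CCCc1ccc(F)cc1)CC2` also returned a limit of > 40000 nM. A limit of this kind is not a measured number, and so compound 2 stands together with the other two, with nothing in the data to set any of them apart: all three sit at the limit of > 40000 nM in this assay, at which 3 of the 3 values shown sit.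

Compound 4 `Cc1ccc(CCCN2CCc3nc(C)c([C@H](OC(C)(C)C)C(=O)O)c(-c4cc(F)c5c(c4C)CCCO5)c3C2)cc1` has not yet been measured. It differs from compound 2 in one place, (methyl in place of fluoro on an aromatic carbon). Among the compounds with values here, no pair of measured compounds differs in a single place, so no measured step shows what a change of this kind does in this assay. Compound 2 gives only a limit, and the step from compound 2 to compound 4 is expected to be a step that the limit leaves unreadable from compound 2 to compound 4, nothing beyond the usual scatter. On that basis compound 4 is estimated at 60000 nM in this assay, within a range of 30000 nM to 200000 nM, and it would most likely be reported once more only as a limit rather than as a number.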

Compound 4, half-maximal cytotoxic concentration: > 40000 nM
Compound 4: a limit, no number; the forecaster's own chance of this, stated with the estimate: 85%; the middle value does not contradict the limit.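

In this assay, within the data shown here, compound 2 and compound 4 both give only a limit, not a number, so no step between them can be read and the two stand alike with the other compounds: the limit of > 40000 nM in this assay, at which 4 of the 4 values shown sit. In this assay the compounds shown leave open at what concentration any of them turns toxic, and whether methyl in place of fluoro on an aromatic carbon changes that concentration at all.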